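Working notes: from compound 1 to compound 3

The source may report more compounds than this note shows. Statements on the series, on what has been measured and on what is new or still open speak of the compounds shown alone.

For the measured compounds named here, compound 1 `Cc1ccccc1-c1nnc(N(N)C(C)C)s1` is the only member of the set with a number in a functional assay on the whole organism with Mus musculus as the target, with a stated time of 1 h; on this read-out higher numbers stand for an effect only at larger amounts of compound and lower numbers for an effect already at smaller amounts; in this assay compound 1 gives 49 mg/kg. Compound 2 `CC(C)N(N)c1nnc(-c2ccccc2Cl)s1` gives in this assay only > 100 mg/kg, which is a limit of the assay and not a number. Going by the values given here, the one measured step, an at least 2.0-fold higher number from compound 1 to compound 2 (0.30 log units; that floor lies within the scatter), rests on the limit of > 100 mg/kg in this assay, at which 1 of the 2 values shown sits, and alters a different part of the molecule, a chloro in place of a methyl on an aromatic carbon.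

Compound 3 `CNN(C)c1nnc(-c2ccccc2C)s1` differs from compound 1 by methyl(methylamino)amino in place of amino(isopropyl)amino on an aromatic carbon. Among the compounds with values here, no measured step touches this part of the structure, so the step from compound 1 to compound 2 does not bear on it, and nothing in the set points in either direction. In this assay compound 3 is therefore expected to give 49 mg/kg, between 20 mg/kg and 120 mg/kg. The step of no change at the digits printed from compound 1 to compound 3 (within the scatter) expected here is one that stays within the usual scatter, with wide uncertainty.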

Compound 3, dose for half-maximal effect: 23 mg/kg
Beside the measured number, compound 3's estimate is 2.1-fold (0.33 log units) above it, and the stated range covers the measured number.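

With methyl(methylamino)amino in place of amino(isopropyl)amino, this position now has a measured step of its own in this assay: a 2.1-fold lower number from compound 1 to compound 3 (0.33 log units; beyond the scatter). The change therefore moves the read-out towards an effect at smaller amounts of compound, so amino(isopropyl)amino is not needed for an effect at this position on the shared core. For the compounds shown here, nothing measured so far gives a reason for this step.

The swap changes the group in more than one respect, so this single pair does not show which part of it carries the step. Still open, going by these compounds, is how a plain amino group, a longer chain such as butylamino or a cyclic amine such as morpholine would read at this position, and whether the step carries over when chloro replaces the methyl on the aromatic carbon.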